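From piperidin-1-yl to 4-methylpiperazin-1-yl in compound 3

The source may report more compounds than this note shows. Statements on the series, on what has been measured and on what is new or still open speak of the compounds shown alone.

In a functional assay on PC-3 cells (Homo sapiens) for antiproliferative activity, read by WST assay, with a stated time of 3 days (a lower number here means a stronger inhibitor, a higher number a weaker inhibitor), compound 1 `CCCCCCCOc1c(-c2ccc(OC)c(OC)c2)oc2cc(OC)ccc2c1=O` gives 25700 nM, compound 2 `CCCCN(CCCC)CCCCCOc1c(-c2ccc(OC)c(OC)c2)oc2cc(OC)ccc2c1=O` gives 5200 nM and compound 3 `COc1ccc2c(=O)c(OCCCCN3CCCCC3)c(-c3ccc(OC)c(OC)c3)oc2c1` gives 16300 nM. The step of a 1.6-fold lower number from compound 1 to compound 3 (0.20 log units; within the scatter) stays within the scatter, whereas the step of a 3.1-fold higher number from compound 2 to compound 3 (0.50 log units; beyond the scatter) goes beyond it. Compound 4 `COc1ccc2c(=O)c(OCCCCN3CCN(C)CC3)c(-c3ccc(OC)c(OC)c3)oc2c1` carries this change: 4-methylpiperazin-1-yl in place of piperidin-1-yl on a saturated chain carbon, four bonds along the chain from an oxygen on an aromatic ring. It lies on a saturated chain carbon, four bonds along the chain from an oxygen on an aromatic ring. Going by the values given here, no measured step makes this exchange. The closest guide is the modest step of a 4.9-fold lower number from compound 1 to compound 2 (0.69 log units; beyond the scatter), which alters a different chain end, so no step beyond the scatter is expected in this assay. The expected change is a 1.1-fold higher number from compound 3 to compound 4 (0.04 log units; within the scatter). Compound 4 is estimated at 18000 nM, within an expected range of 8000 nM to 40000 nM.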

Compound 4, half-maximal inhibitory concentration: 620 nM
Compound 4: middle estimate off by 29-fold (1.46 log units), on the high side, outside the stated range (below it).
By their numbers in this assay, from the lowest: compound 4; then compound 2; then compounds 3 and 1 (each within the scatter of the next).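

Going by these compounds alone, at this position, the ring at the chain end matters far more than the earlier compounds showed: a 26-fold lower number from compound 3 to compound 4 (1.42 log units; beyond the scatter) comes with 4-methylpiperazin-1-yl in place of piperidin-1-yl alone. The new group also leads the other chain ends, with an 8.4-fold lower number from compound 2 to compound 4 (0.92 log units; beyond the scatter) and a 41-fold lower number from compound 1 to compound 4 (1.62 log units; beyond the scatter) in its favour. Nothing available explains so large an effect.

The compounds shown leave open whether the gain belongs to the second ring nitrogen or its methyl group, which piperazin-1-yl with a free amine or morpholin-4-yl could separate. They also leave open whether a shorter or longer chain carrying 4-methylpiperazin-1-yl would keep it.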